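This account rests on a few compounds, and the source may have more. Where it says the series, first, only, none or still open, it means among the compounds named here.

Measured in a functional assay on NCI-H3122 cells (Homo sapiens) for antiproliferative activity, read by MTT assay, with a stated time of 48 h; a higher number here means a weaker inhibitor, a lower number a stronger inhibitor:
Compound 1 `Cc1ccc(CNC(=O)c2cccc(C(C)Oc3cccnc3Nc3nccs3)c2)cc1` gives 15300 nM.
Compound 2 `Cc1ccc(CNC(=O)c2cccc(C(C)Oc3cccnc3Nc3ncc(C)s3)c2)cc1` gives 8500 nM.
Compound 3 `Cc1ccc(CNC(=O)c2cccc(C(C)Oc3ccnc(Nc4cnn(C)c4)c3)c2)cc1` gives 7700 nM.

Compound 1 to compound 2 is the change (methyl in place of hydrogen on an aromatic carbon); the step is a 1.8-fold lower number from compound 1 to compound 2 (0.26 log units; within the scatter). Compound 3 carries a different core; the difference between the two cores is not broken down here. Compound 4 `Cc1ccc(CNC(=O)c2cccc(C(C)Oc3ccnc(Nc4cn(C)nc4C)c3)c2)cc1` is not yet measured in this assay; it stands to compound 3 as methyl in place of hydrogen on an aromatic carbon. This is the same kind of change as from compound 1 to compound 2, not the same: there the methyl entered next to the ring sulfur on a ring with one nitrogen and one sulfur, here it enters next to the ring nitrogen and next to the ring atom that bears a large group, on a ring with two nitrogens. Among the compounds with values here, on the single earlier step, which sits within the scatter, a step of about a 1.4-fold lower number from compound 3 to compound 4 (0.15 log units; within the scatter) is expected for compound 4 in this assay. Compound 4 is estimated at 5500 nM, between 2500 nM and 12000 nM.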

Compound 4, half-maximal inhibitory concentration: 13400 nM
For compound 4 the middle estimate is 2.4-fold (0.39 log units) below the measured one; measured number above the stated range.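

In this assay, methyl in place of hydrogen on an aromatic carbon does not carry over from one core to the other as a fixed step: the same change on two cores in this assay, a 1.8-fold lower number (0.26 log units; within the scatter) from compound 1 to compound 2 and a 1.7-fold higher number (0.24 log units; within the scatter) from compound 3 to compound 4, 3.1-fold (0.50 log units) apart, beyond the scatter of two such steps. The new step, a 1.7-fold higher number from compound 3 to compound 4 (0.24 log units; within the scatter), gives no direction for the methyl on the core of compound 3 when read alone. The gap between the two steps shows only that the outcome differs between these two pairs; it does not show whether the core or the site of the methyl sets that difference, as both differ between the pairs.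

Still open, going by these compounds, is whether the gap recurs with other groups on the same aromatic carbon of the 1-methyl-1H-pyrazol-4-yl ring, such as ethyl, methoxy or an amine. A single pair per core also leaves open how general either step is.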